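The source may hold more compounds than are shown below. What is called first, only, known or untested is meant among the compounds shown, and "the series" means these compounds.

Measured in an ADME assay on Huh-7 cells (Homo sapiens) for cytotoxicity, with a stated time of 72 h; a lower number here means that less compound is tolerated, a higher number that more compound is tolerated:
- Compound 1 `CC(C)CCn1nc(-c2cccs2)c(O)c(C2=NS(=O)(=O)c3cc(NS(=O)(=O)C(C)C)ccc3N2)c1=O`: > 1000 nM, a limit
- Compound 2 `CC(C)CCn1nc(CCC(F)(F)F)c(O)c(C2=NS(=O)(=O)c3cc(NS(C)(=O)=O)ccc3N2)c1=O`: > 33000 nM, a limit
- Compound 3 `CC(C)(C)CCn1nc(-c2cccs2)c(O)c(C2=NS(=O)(=O)c3cc(NS(C)(=O)=O)ccc3N2)c1=O`: > 1000 nM, a limit

None of these results is a number, so the three compounds cannot be ranked. Compound 3 stands only at a limit, > 1000 nM. The results fall at two limits: the limit of > 1000 nM in this assay, at which 2 of the 3 values shown sit, and (the limit of > 33000 nM in this assay, at which 1 of the 3 values shown sits).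

Compound 4 `CS(=O)(=O)Nc1ccc2c(c1)S(=O)(=O)N=C(c1c(O)c(-c3cccs3)nn(CC3CCC3)c1=O)N2` differs from compound 3 in one place: cyclobutyl in place of neopentyl on a saturated chain carbon bound to an aromatic nitrogen. This puts cyclobutyl in place of neopentyl on a saturated chain carbon bound to an aromatic nitrogen. Cut one bond further out, the same difference reads 3,3-dimethylbutyl to cyclobutylmethyl.

Going by the values given here, no two measured compounds differ in one place only, so the data give no direct measure of such a change. Compound 3 is known only as > 1000 nM, and compound 4 is expected to be reported as a limit too. No step beyond the scatter is expected in either direction, and the estimated change is a step that the limit leaves unreadable from compound 3 to compound 4. Compound 4 is estimated at 1500 nM, with an expected range from 700 nM to 33000 nM.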

Compound 4, half-maximal cytotoxic concentration: > 1000 nM
Compound 4 was reported as a limit (the forecaster's own chance of this, stated with the estimate: 85%); the middle value is on the limit's open side.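

Compound 3 and compound 4 are both reported only as limits in this assay, so no step can be read between them. The compounds shown leave open where the half-maximal cytotoxic concentration of either compound lies, and whether cyclobutyl in place of neopentyl on a saturated chain carbon bound to an aromatic nitrogen changes it at all.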